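The source may hold more compounds than are shown below. What is called first, only, known or untested is meant among the compounds shown, and "the series" means these compounds.

- compound 1 `Clc1cccc(C(Nc2ccnc3cc(Cl)ccc23)c2ccc(CN3CCCC3)cc2)c1` gives 9 uM
- compound 2 `Fc1cc(C(Nc2ccnc3cc(C(F)(F)F)ccc23)c2ccc(Cl)cc2)ccc1CN1CCCC1` gives 34 uM

In an ADME assay on NIH3T3 cells (Mus musculus) for cytotoxicity, read by neutral red uptake, with a stated time of 24 h (on this read-out higher numbers stand for lower toxicity in this test and lower numbers for higher toxicity in this test), compound 2 stands highest of the two, and compound 1 lies lower by more than the usual scatter. Compound 3 `Fc1cc(C(Nc2ccnc3cc(Cl)ccc23)c2ccc(Cl)cc2)ccc1CN1CCCC1` differs from compound 2 by having chloro in place of trifluoromethyl on an aromatic carbon. Within the data shown here, no measured pair shows this change alone. Compound 1 also carries chloro at that place, differs elsewhere too, and gives 9 uM. A modest downward step, close to the scatter, is expected a 1.9-fold lower number from compound 2 to compound 3 (0.28 log units; within the scatter). For compound 3 the estimated value is 18 uM, with an expected range of 7 uM to 42 uM.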

Compound 3, half-maximal toxic concentration: 25 uM
Beside the measured number, compound 3's estimate is 1.4-fold (0.14 log units) below it; the range from low to high includes it.
By their numbers in this assay, from the lowest: compound 1; then compounds 3 and 2 (each within the scatter of the next).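

In this assay, chloro in place of trifluoromethyl on an aromatic carbon gives a 1.4-fold lower number from compound 2 to compound 3 (0.13 log units; within the scatter), so this one exchange at this place leaves the two compounds indistinguishable. Compound 2 and compound 3 are the only pair shown that isolates this change, since compound 1 differs from each in more than one place. Nothing available bears on why the exchange behaves this way. As far as these compounds go, how a nitrile, a methoxy group or an amine at this place would read remains open. So does whether the same step would hold if other parts of the shared core were different.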